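Methoxy for Chloro in a Cytotoxicity Series

This account rests on a few compounds, and the source may have more. Where it says the series, first, only, none or still open, it means among the compounds named here.

Compound 2 `Cn1ccc2c(Oc3ccc(NC(=O)c4nn(-c5ccc(Cl)cc5)ccc4=O)cc3F)ccnc21` was tested in a functional assay on MCF7 cells (Homo sapiens) for cytotoxicity, read by MTT assay, with a stated time of 72 h; a lower number here means a stronger inhibitor, a higher number a weaker inhibitor. In this assay compound 2 gives > 60000 nM, which is a limit of the assay rather than a measured number. Compound 1 `COc1ccc(-n2ccc(=O)c(C(=O)Nc3ccc(Oc4ccnc5c4ccn5C)cc3)n2)cc1` gives > 60000 nM in this assay, again a limit. Everything known so far thus rests on (the limit of > 60000 nM in this assay, at which 2 of the 2 values shown sit). Compound 3 `COc1ccc(-n2ccc(=O)c(C(=O)Nc3ccc(Oc4ccnc5c4ccn5C)c(F)c3)n2)cc1` is the new compound, carrying methoxy in place of chloro on an aromatic carbon. Within the data shown here, no measured step offers guidance, so a step that the limit leaves unreadable from compound 2 to compound 3 is expected, meaning no change beyond the scatter. Compound 3 is estimated at 100000 nM, within 30000 nM to 500000 nM, and most likely reported again only as a limit.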

Compound 3, half-maximal inhibitory concentration: > 60000 nM
Compound 3: no number, only a limit; the forecaster's own chance of this, stated with the estimate: 85%; the middle value lies beyond the limit too.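

Among these compounds, compound 1, compound 2 and compound 3 are each reported only as a limit, so no step between them can be read: the limit of > 60000 nM in this assay, at which 3 of the 3 values shown sit. The compounds shown leave open whether methoxy in place of chloro, or fluoro in place of hydrogen, changes cytotoxicity at all.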